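The source may report more compounds than this note shows. Statements on the series, on what has been measured and on what is new or still open speak of the compounds shown alone.

Measured so far:
compound 1 `COc1ccccc1/C=C/c1ccccc1OCCCCN(C)C`: 0%
compound 2 `CCCOC1CCCN(CCCCOc2ccccc2/C=C/c2ccccc2)C1`: 0%

In a functional assay on the whole organism with Mus musculus as the target, in the maximal electroshock model, at a dose of 50 mg/kg by the oral route (on this read-out higher numbers stand for more inhibition at the one dose given (going by the name of the read-out) and lower numbers for less inhibition), compound 1 gives 0%, and compound 2 gives 0%. On these numbers compound 2 stands level with compound 1, with no change beyond the scatter. Compound 3 `COC(=O)C1CCCN(CCCCOc2ccccc2/C=C/c2ccccc2)C1` is not yet measured in this assay. It differs from compound 2 in one place: methoxycarbonyl in place of propoxy on a saturated ring carbon. Within the data shown here, no measured pair shows what this change does. Because compound 2 gives 0%, the expected step is no change at the digits printed from compound 2 to compound 3 (within the scatter), none beyond the scatter. Compound 3 is expected to give 0% in this assay, within 0% to 15%.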

Compound 3, a percentage reported as inhibition, in the whole organism at one dose (the size of the read-out at that dose, not a potency): 0%
Compound 3: the middle estimate sits on the measured number at the digits printed; the range from low to high includes it.
By their numbers in this assay, from the lowest: compounds 1, 2 and 3 (each within the scatter of the next).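

Among these compounds, this is the first measured step at this position: in this assay, methoxycarbonyl in place of propoxy on a saturated ring carbon, two ring bonds from the ring nitrogen, gives no change at the digits printed from compound 2 to compound 3 (within the scatter). Swapping an ether-linked chain for an ester of the same heavy-atom count therefore brings no inhibition at this dose, and the pair cannot rank the two groups. Still open, on these data alone, is whether a carboxylic acid or an amine on this ring carbon would give any inhibition in this assay. Nothing available bears on the reason for this result.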